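A few compounds are considered here, and "the series" means these few. Any claim that something is new, unique, unknown or untested is made for them only; others in the source may bear on it.

The compounds measured so far:

Compound 1, `CC(C)N1CCc2nc(C#Cc3ccccc3)ccc2C1=O`, 1280 nM
Compound 2, `Cc1ccccc1C#Cc1ccc2c(n1)CCN(C(C)C)C2=O`, > 32000 nM
Compound 3, `CC(C)N1CCc2nc(C#Cc3ccc(Cl)cc3)ccc2C1=O`, 27100 nM

The three share one core and differ only in the aromatic ring on the triple-bonded carbon. In an assay on HEK293 cells for displacement of a labelled ligand from metabotropic glutamate receptor 5 (Homo sapiens), with a stated time of 2 h (on this read-out higher numbers stand for weaker inhibition and lower numbers for stronger inhibition), compound 1 gives 1280 nM. For compound 2 the result is a limit of this assay, (the limit of > 32000 nM in this assay, at which 1 of the 3 values shown sits), so no number is known for it. Compound 3 stands at the highest of the two numbers; the nearest number is that of compound 1, and the step of a 21-fold higher number from compound 1 to compound 3 (1.33 log units; beyond the scatter) comes with chloro in place of hydrogen on an aromatic carbon. The step of an at least 25-fold higher number from compound 1 to compound 2 (1.39 log units; beyond the scatter) is of similar size. Between compound 2 and compound 3 the step of an at least 1.1-fold lower number from compound 2 to compound 3 (0.07 log units; that floor lies within the scatter) shows no difference beyond the scatter.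

Compound 4 is `CC(C)N1CCc2nc(C#Cc3ccccn3)ccc2C1=O`. The change from compound 3 is pyridin-2-yl in place of 4-chlorophenyl on a triple-bonded carbon. Among the measured compounds shown here, the chloro whose entry gave a 21-fold higher number from compound 1 to compound 3 (1.33 log units; beyond the scatter) leaves here, so a return toward the number of compound 1 is expected; the ring nitrogen entering has no counterpart among the measured compounds, so its effect is unknown. Compound 4 is therefore expected to give 1500 nM, between 400 nM and 6000 nM, which means an expected step of an 18-fold lower number from compound 3 to compound 4 (1.26 log units; beyond the scatter).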

Compound 4, inhibition constant: 2740 nM
Compound 4: middle estimate off by 1.8-fold (0.26 log units), on the low side; the range from low to high includes it.
By their numbers in this assay, from the lowest: compound 1; then compound 4; then compound 3. At a limit, above all of these: compound 2.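

Of the three replacements for the phenyl of compound 1 on the triple-bonded carbon, pyridin-2-yl moves the number least, with a 2.1-fold higher number from compound 1 to compound 4 (0.33 log units; beyond the scatter), but that step still lies beyond the scatter, so none of the rings shown matches phenyl in this assay. The position is therefore not closed to every change of ring: pyridin-2-yl recovers most of the loss seen with the substituted phenyl rings, giving a 9.9-fold lower number from compound 3 to compound 4 (1.00 log units; beyond the scatter) and also an at least 11-fold lower number from compound 2 to compound 4 (1.06 log units; beyond the scatter), so a ring nitrogen costs much less here than either the chloro or the methyl. The second of these steps is only a floor, as compound 2 stands at a limit and not at a number: the limit of > 32000 nM in this assay, at which 1 of the 4 values shown sits.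

The compounds shown leave open whether the place of the nitrogen in the ring matters, as pyridin-3-yl and pyridin-4-yl would show, and whether a fluoro or a methoxy on the phenyl ring would cost as much as the chloro or the methyl. They also leave open whether these steps would hold on a core carrying a cyclopropyl or a methyl in place of the isopropyl.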